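The source may hold more compounds than are shown below. What is called first, only, known or untested is meant among the compounds shown, and "the series" means these compounds.

Measured compounds:
- compound 1, `O=C(OC1(C(=O)Nc2ccc([N+](=O)[O-])cc2)CCCCC1)c1ccc(C(F)(F)F)cc1`: 185 nM
- compound 2, `O=C(OC1(C(=O)Nc2ccc([N+](=O)[O-])cc2)CCCCC1)c1ccc([N+](=O)[O-])cc1`: 761 nM
- compound 3, `CCOC(=O)c1ccccc1C(=O)OC1(C(=O)Nc2ccc([N+](=O)[O-])cc2)CCCCC1`: 386 nM

In an ADME assay on WI-38 cells (Homo sapiens) for inhibition, read by MTT assay, with a stated time of 72 h (on this read-out lower numbers stand for stronger inhibition and higher numbers for weaker inhibition), compound 2 gives the highest of the three numbers. Compound 3 sits within the scatter of it, and compound 1 lies beyond the scatter below it, as shown by a 4.1-fold higher number from compound 1 to compound 2 (0.61 log units; beyond the scatter).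

Compound 4, `O=C(OC1(C(=O)Nc2ccc([N+](=O)[O-])cc2)CCCCC1)C(O)c1ccccc1`, is not yet measured. Its change from compound 2 is hydroxy(phenyl)methyl in place of 4-nitrophenyl on a carbonyl carbon. Within the data shown here, the only measured step that touches the ester aryl group is the one from compound 1 to compound 2, where the nitro entered; compound 3, with an ethoxycarbonyl-bearing aryl in that position, is within the scatter of compound 2. Among the measured compounds shown here, the change to compound 4 removes the nitro group from that aryl and brings in a hydroxy-bearing carbon, which no measured pair covers. Since compound 1 without the nitro shows 185 nM, the expected step of a 1.9-fold lower number from compound 2 to compound 4 (0.28 log units; within the scatter) is downward but modest and uncertain. Compound 4 is therefore estimated at 400 nM, with a range from 150 nM to 1200 nM.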

Compound 4, half-maximal inhibitory concentration: 84.4 nM
Beside the measured number, compound 4's estimate is 4.7-fold (0.68 log units) above it; measured number below the stated range.
By their numbers in this assay, from the lowest: compound 4; then compound 1; then compounds 3 and 2 (each within the scatter of the next).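

In this assay, the carbonyl carbon of the ester accepts more than the substituted aryl groups seen so far: hydroxy(phenyl)methyl in place of 4-nitrophenyl gives the larger step (a 9.0-fold lower number from compound 2 to compound 4 (0.96 log units; beyond the scatter)), and in place of 4-(trifluoromethyl)phenyl it gives a smaller one (a 2.2-fold lower number from compound 1 to compound 4 (0.34 log units; beyond the scatter)). Among these compounds, both steps lie beyond the scatter, so in these two pairs the group with a hydroxy-bearing carbon ends lower than the aryl group it replaces, which the earlier compounds could not show. No measured evidence bears on the reason for this change in the number.

The compounds shown leave open whether the hydroxy group, the added carbon or the loss of the aryl substituent carries the step. A plain benzyl group, or an amine in place of the hydroxy group, would separate these readings.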